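The compounds below may be only part of what the source reports. "The series", "measured", "known", "first", "only" and "open" are said of these compounds alone.

Compound 1 `COc1cc(OC)c2c(=O)cc(-c3ccc(OCCF)cc3)oc2c1`: 21%
Compound 2 `COc1cc(OC)c2c(=O)cc(-c3ccc(OCC(O)CN4CCCC4)cc3)oc2c1`: 57%

Within the data shown here, in a functional assay (Homo sapiens) for antiproliferative activity, read by resazurin assay, with a stated time of 48 h, tested at 20 uM (a lower number here means a weaker effect, a higher number a stronger effect of the compound at the concentration tested), compound 2 holds the higher of the two numbers; the only other measured compound, compound 1, sits well below it. Among the measured compounds shown here, that gap is the one measured step, a number 36 percentage points higher from compound 1 to compound 2 (beyond the scatter), and it arose when a large side chain replaced a small group.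

Compound 3 `COc1cc(OC)c2c(=O)cc(-c3ccc(Br)cc3)oc2c1` differs from compound 2 by bromo in place of 2-hydroxy-3-(pyrrolidin-1-yl)propoxy on an aromatic carbon. Since a large group again gives way to a small one, the drop is expected to mirror that step, roughly a number 32 percentage points lower from compound 2 to compound 3 (beyond the scatter). Compound 3 is estimated at 25%, with a likely range from 10% to 45%.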

Compound 3, a percentage reported as inhibition, at one concentration (the size of the read-out at that concentration, not a potency): 22%
Compound 3: the middle estimate sits 3 percentage points above what was measured; low and high end bracket the measured number.
By their numbers in this assay, from the lowest: compounds 1 and 3 (each within the scatter of the next); then compound 2.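

Against bromo, the 2-hydroxy-3-(pyrrolidin-1-yl)propoxy side chain again stands apart in this assay, with a number 35 percentage points lower from compound 2 to compound 3 (beyond the scatter) on swapping it out. Exchanging 2-fluoroethoxy for bromo makes no readable difference, with a number 1 percentage points higher from compound 1 to compound 3 (within the scatter) in this pair, so at this position both small groups sit well apart from the side chain. Nothing measured here explains this gap.

Still open, from the compounds shown here alone, is which part of the side chain matters. A 3-(pyrrolidin-1-yl)propoxy chain without the hydroxyl, or a piperidine or morpholine in place of the pyrrolidine, would help separate the roles of the hydroxyl and the amine.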